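Shifting the aryl substituent on the triazole-bound phenyl

The source may hold more compounds than are shown below. What is called first, only, known or untested is meant among the compounds shown, and "the series" means these compounds.

Three analogues have been measured in a functional assay on OVCAR-3 cells (Homo sapiens) for antiproliferative activity, read by MTT assay, with a stated time of 24 h; a higher number here means a weaker inhibitor, a lower number a stronger inhibitor. Compound 1 `Cc1ccccc1-n1cc(-c2ccccc2NS(=O)(=O)c2c[nH]c(=O)[nH]c2=O)nn1` gives 6550 nM, compound 2 `Cc1cccc(-n2cc(-c3ccccc3NS(=O)(=O)c3c[nH]c(=O)[nH]c3=O)nn2)c1` gives 3150 nM, and compound 3 `Cc1ccc(-n2cc(-c3ccccc3NS(=O)(=O)c3c[nH]c(=O)[nH]c3=O)nn2)cc1` gives 2190 nM. Compound 2 stands second highest of the three: its gap to compound 3 is a 1.4-fold lower number from compound 2 to compound 3 (0.16 log units; within the scatter), while the step of a 2.1-fold lower number from compound 1 to compound 2 (0.32 log units; beyond the scatter) separates it from compound 1. Compound 4 `O=c1[nH]cc(S(=O)(=O)Nc2ccccc2-c2cn(-c3ccccc3Cl)nn2)c(=O)[nH]1` differs from compound 2 by 2-chlorophenyl in place of 3-methylphenyl on an aromatic nitrogen. Among the compounds with values here, the only step that bears on this change is a 2.1-fold lower number from compound 1 to compound 2 (0.32 log units; beyond the scatter), which ran in the opposite direction; the chlorine has no precedent among the measured compounds. The expected step is therefore a modest rise in the number, a 1.7-fold higher number from compound 2 to compound 4 (0.24 log units; within the scatter), and compound 4 is estimated at 5500 nM, within a range from 2500 nM to 12000 nM.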

Compound 4, half-maximal inhibitory concentration: 3170 nM
Beside the measured number, compound 4's estimate is 1.7-fold (0.24 log units) above it; low and high end bracket the measured number.
By their numbers in this assay, from the lowest: compounds 3, 2 and 4 (each within the scatter of the next); then compound 1.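

In this assay the swap of chloro for methyl gives a 2.1-fold lower number from compound 1 to compound 4 (0.32 log units; beyond the scatter) and so the high number of compound 1 does not carry over to the 2-chlorophenyl group. That group stands level with both remaining methylphenyl groups, with a 1.0-fold higher number from compound 2 to compound 4 (0.00 log units; within the scatter) and a 1.4-fold higher number from compound 3 to compound 4 (0.16 log units; within the scatter) as the two readings. Nothing measured here accounts for the difference between chloro and methyl. Still open, from the compounds shown here alone, is how 3-chlorophenyl and 4-chlorophenyl would compare with 2-chlorophenyl. Also open, going by these compounds, is whether a methoxy group or an amine on this phenyl would separate from compounds 2, 3 and 4.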